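Chloro for Methoxy: Where Compound 4 Might Fall

The source may report more compounds than this note shows. Statements on the series, on what has been measured and on what is new or still open speak of the compounds shown alone.

Compound 1, `CCc1ccc(C(=O)OCc2cn(-c3ccnc4cc(Cl)ccc34)nn2)cc1`: in an ADME assay on HepG2 cells (Homo sapiens) for cytotoxicity, read by MTT assay, with a stated time of 24 h (a higher number here means that more compound is tolerated, a lower number that less compound is tolerated), compound 1 gives > 2550000 nM, which is a limit of the assay and not a number.
Compound 2, `CCc1ccccc1C(=O)OCc1cn(-c2ccnc3cc(Cl)ccc23)nn1`: compound 2 gives > 2550000 nM, again a limit of the assay rather than a number.
Compound 3, `COc1ccc(C(=O)OCc2cn(-c3ccnc4cc(Cl)ccc34)nn2)cc1`: compound 3 gives 303000 nM.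

Within the data shown here, compound 3 therefore stands as the only compound of the three with a measured number; the other two sit at the limit of > 2550000 nM in this assay, at which 2 of the 3 values shown sit. The step that the two limits leave unreadable from compound 1 to compound 2 cannot be read, because both ends are limits. The steps of an at least 8.4-fold lower number from compound 1 to compound 3 (0.92 log units; beyond the scatter) and an at least 8.4-fold lower number from compound 2 to compound 3 (0.92 log units; beyond the scatter) show that a change at this position of the ester can move the read-out beyond the scatter, in both cases toward less tolerated compound.

Compound 4, `O=C(OCc1cn(-c2ccnc3cc(Cl)ccc23)nn1)c1ccc(Cl)cc1`, differs from compound 3 by chloro in place of methoxy on an aromatic carbon. Among the measured compounds shown here, no measured step exchanges methoxy for chloro, so the direction of the step rests on no direct precedent. The measured steps bear on it only in showing that this position matters; they do not say whether chloro behaves like methoxy or like ethyl.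

Weighing the single number against the two limits, compound 4 is expected to give about 800000 nM, within a range from 200000 nM to 2550000 nM. This estimate means an expected step of a 2.6-fold higher number from compound 3 to compound 4 (0.42 log units; beyond the scatter), with a fair chance that only a limit is reported.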

Compound 4, half-maximal cytotoxic concentration: 484000 nM
Compound 4: middle estimate off by 1.7-fold (0.22 log units), on the high side; the measured number falls inside the stated range.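

In this assay, exchanging methoxy for chloro gives a 1.6-fold higher number from compound 3 to compound 4 (0.20 log units; within the scatter), so on this aromatic carbon, para to a large group, the two groups cannot be told apart. The gap to the ethyl compounds therefore does not belong to methoxy alone: chloro in place of ethyl gives an at least 5.2-fold lower number from compound 1 to compound 4 (0.72 log units; beyond the scatter), and 4-chlorophenyl in place of 2-ethylphenyl gives an at least 5.2-fold lower number from compound 2 to compound 4 (0.72 log units; beyond the scatter). Compound 3 and compound 4 now stand together with measured numbers, while compound 1 and compound 2 carry only a limit and not a number: the limit of > 2550000 nM in this assay, at which 2 of the 4 values shown sit.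

As far as these compounds go, how large the steps from the two ethyl compounds really are stays open. So does whether an amine, a carboxylic acid or a longer chain on this carbon would side with chloro and methoxy or with ethyl.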